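Swapping the aryl amide on a dimethylaminopyrimidine core

The source may hold more compounds than are shown below. What is called first, only, known or untested is meant among the compounds shown, and "the series" means these compounds.

Measured compounds:
- Compound 1 `CCN(C)c1nc(N[C@H]2CC[C@@H](NC(=O)c3ccc(F)c(F)c3)CC2)ncc1C`: 46 nM
- Compound 2 `Cc1cc(N(C)C)nc(N[C@H]2CC[C@@H](NC(=O)c3cccc(Cl)c3)CC2)n1`: 6.5 nM
- Compound 3 `Cc1cc(N(C)C)nc(N[C@H]2CC[C@@H](NC(=O)c3ccc(OC(F)(F)F)cc3)CC2)n1`: 230 nM

All three compounds were tested in a functional assay on HEK293 cells for antagonist activity at melanin-concentrating hormone receptor 1 (Homo sapiens), read by FLIPR and calcium flux; on this read-out lower numbers stand for stronger inhibition and higher numbers for weaker inhibition. Compound 2 gives the lowest number of the three, 6.5 nM. Compound 1 gives 46 nM; its gap from compound 2 lies well outside the scatter. Compound 3 gives 230 nM; its gap from compound 2 is larger still and also outside the scatter. For the measured compounds named here, compound 1 differs from compound 2 in more than one place, so its value says only that a compound carrying the 3,4-difluorophenyl amide on a different core is clearly weaker than compound 2.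

Compound 4 `Cc1cc(N(C)C)nc(N[C@H]2CC[C@@H](NC(=O)c3ccc(F)c(F)c3)CC2)n1` has not been measured. It keeps the shared core of compound 2 and carries a single change: 3,4-difluorophenyl in place of 3-chlorophenyl on a carbonyl carbon. Going by the values given here, no step between two measured compounds matches this change, so the expectation rests only on the values shown. The step from compound 2 to compound 4 in this assay is expected to be a modest rise, a 2.3-fold higher number from compound 2 to compound 4 (0.36 log units; beyond the scatter), near the edge of the scatter. Compound 4 is estimated at 15 nM, with a likely range from 5 nM to 50 nM.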

Compound 4, half-maximal inhibitory concentration: 2.5 nM
Compound 4: the middle estimate sits 6.0-fold (0.78 log units) above what was measured; measured number outside the range, below it.
By their numbers in this assay, from the lowest: compound 4; then compound 2; then compound 1; then compound 3.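

On the shared core of compound 2, 3,4-difluorophenyl in place of 3-chlorophenyl on a carbonyl carbon gives a 2.6-fold lower number from compound 2 to compound 4 (0.41 log units; beyond the scatter) in this assay, a modest step that lies beyond the scatter. For the compounds shown here, this is the only pair here that differs in one place, so it gives the first clean reading of this position: the aryl group on the amide can be exchanged here and the number still falls. Nothing available explains this difference.

Still open, going by these compounds, is what each fluorine contributes, which 3-fluorophenyl and 4-fluorophenyl amides on the shared core could separate. Also open, on these data alone, is how this carbonyl carbon tolerates groups such as an unsubstituted phenyl, a pyridine ring or a saturated cyclohexyl ring.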